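Methyl position and cytotoxicity in three methylphenyl isomers

The compounds below may be only part of what the source reports. "The series", "measured", "known", "first", "only" and "open" are said of these compounds alone.

In an ADME assay on Vero 76 cells (Chlorocebus sabaeus) for cytotoxicity, read by MTT assay, with a stated time of 5 days (on this read-out higher numbers stand for lower toxicity in this test and lower numbers for higher toxicity in this test), compound 1 `NS(=O)(=O)c1ccc(N2N=C(c3ccc(Oc4ccccc4)cc3)CC2c2ccccc2)cc1`, which carries no methyl, gives 35000 nM. The 3-methylphenyl analogue, compound 2 `Cc1cccc(C2CC(c3ccc(Oc4ccccc4)cc3)=NN2c2ccc(S(N)(=O)=O)cc2)c1`, gives 14000 nM, and the 4-methylphenyl analogue, compound 3 `Cc1ccc(C2CC(c3ccc(Oc4ccccc4)cc3)=NN2c2ccc(S(N)(=O)=O)cc2)cc1`, gives 20000 nM. Adding the methyl in the first case gives a 2.5-fold lower number from compound 1 to compound 2 (0.40 log units; beyond the scatter), a modest step. Compound 3 sits within the scatter of both other compounds, as shown by a 1.8-fold lower number from compound 1 to compound 3 (0.24 log units; within the scatter) and by a 1.4-fold higher number from compound 2 to compound 3 (0.15 log units; within the scatter).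

The next compound to be tested is compound 4 `Cc1ccccc1C1CC(c2ccc(Oc3ccccc3)cc2)=NN1c1ccc(S(N)(=O)=O)cc1`, with 2-methylphenyl in place of 4-methylphenyl on a saturated ring carbon, next to the ring nitrogen: 2-methylphenyl in place of 4-methylphenyl on a saturated ring carbon. The same kind of change, a methyl moved around the same phenyl ring, has been seen only once, in a 1.4-fold higher number from compound 2 to compound 3 (0.15 log units; within the scatter), and that step stays within the scatter. Going by the values given here, the steps that add a methyl are also small, but no measured compound yet carries 2-methylphenyl, so this position remains untested. On this evidence, the estimated 1.1-fold lower number from compound 3 to compound 4 (0.05 log units; within the scatter) is expected to stay within the scatter, with no clear direction. The estimated value for compound 4 is 18000 nM, with an expected range of 9000 nM to 36000 nM.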

Compound 4, half-maximal cytotoxic concentration: 14000 nM
Compound 4: middle estimate off by 1.3-fold (0.11 log units), on the high side; the measured number falls inside the stated range.
By their numbers in this assay, from the lowest: compounds 2, 4, 3 and 1 (each within the scatter of the next, the first and the last beyond it).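

In this assay, 2-methylphenyl on the saturated ring carbon adds a third methyl position to the comparison, and a 1.4-fold lower number from compound 3 to compound 4 (0.15 log units; within the scatter) and no change at the digits printed from compound 2 to compound 4 (within the scatter) both stay within the scatter, so none of the three methylphenyl isomers can be separated from the others by methyl position. Compared with the methyl-free compound 1, the new compound shows a 2.5-fold lower number from compound 1 to compound 4 (0.40 log units; beyond the scatter), a modest step beyond the scatter and the same size as a 2.5-fold lower number from compound 1 to compound 2 (0.40 log units; beyond the scatter), which gives a second case of a methyl lowering the number; compound 3 goes against this as a general pattern, since a 1.8-fold lower number from compound 1 to compound 3 (0.24 log units; within the scatter) stays within the scatter. Nothing available on these compounds bears on what lies behind these numbers.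

The compounds shown leave open whether a group other than methyl on this phenyl ring, such as a methoxy, a chlorine, an amine or a carboxylic acid, would stay in the same range or move the number clearly. They also leave open whether a longer chain such as ethyl, or a second methyl on the same ring, would widen the modest step seen from compound 1.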